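Third aryl variation on the same nitrogen: compound 4

A few compounds are considered here, and "the series" means these few. Any claim that something is new, unique, unknown or untested is made for them only; others in the source may bear on it.

Compound 1 `N#CC1=C(N)Oc2c(c3nc4ccccc4nc3c3ccccc23)C12C(=O)N(Cc1cnnn1-c1ccccc1Cl)c1ccccc12` is the anchor of this small set. Within the data shown here, in a functional assay on A549 cells (Homo sapiens) for antiproliferative activity, read by MTT assay, with a stated time of 48 h (a higher number here means a weaker inhibitor, a lower number a stronger inhibitor), compound 1 gives 42600 nM, the only definite number among the three measured compounds. Compound 2 `CCOc1ccccc1-n1nncc1CN1C(=O)C2(C(C#N)=C(N)Oc3c2c2nc4ccccc4nc2c2ccccc32)c2ccccc21` carries ethoxy in place of chloro on an aromatic carbon. In this assay compound 2 returns only a limit of the assay, > 50000 nM. Compound 3 `N#CC1=C(N)Oc2c(c3nc4ccccc4nc3c3ccccc23)C12C(=O)N(Cc1cnnn1-c1ccc([N+](=O)[O-])cc1)c1ccccc12` carries 4-nitrophenyl in place of 2-chlorophenyl on an aromatic nitrogen. In this assay compound 3 also returns a limit, > 50000 nM. The measured steps are accordingly floors rather than sizes: an at least 1.1-fold higher number from compound 1 to compound 2 (0.06 log units; that floor lies within the scatter), an at least 1.1-fold higher number from compound 1 to compound 3 (0.06 log units; that floor lies within the scatter), and between the two limits a step that the two limits leave unreadable from compound 2 to compound 3. The set as a whole sits at the limit of > 50000 nM in this assay, at which 2 of the 3 values shown sit.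

Compound 4 `N#CC1=C(N)Oc2c(c3nc4ccccc4nc3c3ccccc23)C12C(=O)N(Cc1cnnn1-c1cccc(S(N)(=O)=O)c1)c1ccccc12` differs from compound 1 in one place: 3-sulfamoylphenyl in place of 2-chlorophenyl on an aromatic nitrogen. Among the measured compounds shown here, the steps that bear on it are the two other variations of the aryl on the same aromatic nitrogen, and each of them gives only a floor that lies within the scatter; no direction beyond the scatter is established, though both variations moved away from the one definite number. Compound 4 is therefore expected in this assay near 60000 nM, with a range from 20000 nM to 180000 nM, with a real chance that only a limit is reported. The expected step is a 1.4-fold higher number from compound 1 to compound 4 (0.15 log units; within the scatter).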

Compound 4, half-maximal inhibitory concentration: 44200 nM
The estimate for compound 4 lay 1.4-fold (0.13 log units) above the measured number, within the range that was stated.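

In this assay, 3-sulfamoylphenyl in place of 2-chlorophenyl on the aromatic nitrogen gives a 1.0-fold higher number from compound 1 to compound 4 (0.02 log units; within the scatter), so this position now carries two definite numbers that cannot be told apart. The chlorine is therefore not required for a definite number at this position, since an aryl group without it, with more heavy atoms and with a hydrogen-bond donor and acceptors that 2-chlorophenyl lacks, also gives one. Against the two aryl groups that returned only limits, the readings are floors, an at least 1.1-fold lower number from compound 3 to compound 4 (0.05 log units; that floor lies within the scatter) and an at least 1.1-fold lower number from compound 2 to compound 4 (0.05 log units; that floor lies within the scatter), so no separation from either group is established, and much of the set remains at the edge of the assay: the limit of > 50000 nM in this assay, at which 2 of the 4 values shown sit.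

On these data alone, it remains open whether any group on this nitrogen can move the number beyond the scatter, for example a phenyl ring bearing an amine or a carboxylic acid, or a simple alkyl chain in place of the aryl ring. How far the sulfamoyl result depends on where that group sits on the phenyl ring also stays unresolved, as 3-sulfamoylphenyl is the only sulfamoyl-bearing aryl group shown.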